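Aryl sulfamate series: replacing the bromobenzyl amine

A few compounds are considered here, and "the series" means these few. Any claim that something is new, unique, unknown or untested is made for them only; others in the source may bear on it.

Compound 2 `CCN(Cc1ccc(Br)cc1)c1ccc(C(=O)N2CCc3ccc(OS(N)(=O)=O)cc3C2)cc1` gives 95.9% in an assay on HEK293 cells for inhibition of Steryl-sulfatase (Homo sapiens), tested at 1 uM (on this read-out lower numbers stand for a weaker effect and higher numbers for a stronger effect at the one concentration tested), the highest of the three numbers measured. Compound 1 `CCN(Cc1cccnc1)c1ccc(C(=O)N2CCc3ccc(OS(N)(=O)=O)cc3C2)cc1` gives 85.2% in this assay, and the step of a number 10.7 percentage points higher from compound 1 to compound 2 (beyond the scatter) lies beyond the scatter. Within the data shown here, compound 3 `CN(C)CCN(Cc1ccccc1)c1cccc(C(=O)N2CCc3ccc(OS(N)(=O)=O)cc3C2)c1` gives 28.6%; it differs from compound 2 in more than one place, so no single step links them, and its number stands far below that of compound 2.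

Compound 4 `CN(CCN1CCCCC1)c1ccc(C(=O)N2CCc3ccc(OS(N)(=O)=O)cc3C2)cc1` is not yet measured. It differs from compound 2 by methyl(2-(piperidin-1-yl)ethyl)amino in place of (4-bromobenzyl)(ethyl)amino on an aromatic carbon. Among the measured compounds shown here, no measured step covers this kind of change: the one step known, from compound 1 to compound 2, only exchanges one aromatic ring for another on the chain carbon and is modest. The closest hint is compound 3, which also bears a chain amine rather than a benzyl group and reads 28.6%, though it also differs in where the amide sits. A decrease beyond the scatter is therefore expected, a number 50.9 percentage points lower from compound 2 to compound 4 (beyond the scatter), with wide uncertainty. Compound 4 is estimated at 45%, between 15% and 80%.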

Compound 4, a percentage reported as inhibition, at one concentration (the size of the read-out at that concentration, not a potency): 26.8%
Beside the measured number, compound 4's estimate is 18.2 percentage points above it; the range from low to high includes it.
By their numbers in this assay, from the lowest: compounds 4 and 3 (each within the scatter of the next); then compound 1; then compound 2.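

Among these compounds, at the aromatic carbon para to a large group, the earlier step exchanged only one aromatic ring for another, whereas in this assay methyl(2-(piperidin-1-yl)ethyl)amino in place of (4-bromobenzyl)(ethyl)amino gives a number 69.1 percentage points lower from compound 2 to compound 4 (beyond the scatter) and in place of ethyl((pyridin-3-yl)methyl)amino gives a number 58.4 percentage points lower from compound 1 to compound 4 (beyond the scatter). The large drop therefore appears with either aromatic group as the leaving partner, so this position does not accept every amine substituent equally. Nothing measured here accounts for the loss.

This change replaces the aromatic ring, the chain and the ethyl group together, which leaves open which part carries the loss. Amines such as (4-bromobenzyl)(methyl)amino and ethyl(2-(piperidin-1-yl)ethyl)amino would each separate one part of that change.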